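Replacing chloro with propoxy in compound 1

The source may hold more compounds than are shown below. What is called first, only, known or untested is meant among the compounds shown, and "the series" means these compounds.

compound 1 `O=C(O)c1cc(NC(=O)c2ccc(Cl)cc2)cc(C(=O)O)c1` gives 97.3 mg/kg
compound 2 `O=C(Nc1ccccc1)c1ccc(-c2nn[nH]n2)cc1` gives 40 mg/kg

In a functional assay on the whole organism (stomach) with Rattus norvegicus as the target (a higher number here means that more compound is needed for the effect, a lower number that less compound is needed), compound 1 stands highest of the two measured compounds. Its number lies above that of compound 2 by a gap beyond the usual scatter. Compound 3 `CCCOc1ccc(C(=O)Nc2cc(C(=O)O)cc(C(=O)O)c2)cc1` has not yet been measured. It keeps the core of compound 1 and carries a single change, propoxy in place of chloro on an aromatic carbon, para to a large group (propoxy in place of chloro on an aromatic carbon). Going by the values given here, no measured pair in this small set shows what such an exchange does, and compound 2 differs from compound 1 in more than one place, so the expectation rests on very little. In this assay the estimated step is a 1.6-fold lower number from compound 1 to compound 3 (0.21 log units; within the scatter) and it is expected to point toward a somewhat lower number without going beyond the usual scatter. For compound 3 the estimate is 60 mg/kg with a wide expected range (20 mg/kg to 180 mg/kg).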

Compound 3, dose for 50% inhibition: 78 mg/kg
For compound 3 the middle estimate is 1.3-fold (0.11 log units) below the measured one; the range from low to high includes it.
By their numbers in this assay, from the lowest: compounds 2, 3 and 1 (each within the scatter of the next, the first and the last beyond it).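

In this assay, the exchange of chloro for propoxy on an aromatic carbon, para to a large group, gives a 1.2-fold lower number from compound 1 to compound 3 (0.10 log units; within the scatter) and stays within the usual scatter. Going by these compounds alone, this is the first pair in the set that differs in one place, and so the first direct reading of this position: the substituent grows from one heavy atom to four and gains a hydrogen-bond acceptor, yet the two compounds cannot be told apart in this assay. No measurement available here offers an explanation for this outcome.

The compounds shown leave open whether this tolerance extends to other groups at the same place, such as a shorter methoxy, a longer butoxy chain or an amine, since one exchange cannot show how far the position accepts change. They also leave open whether propoxy would behave in the same way on another core, as compound 2 differs from compound 1 in more than one place and offers no matched comparison for this exchange.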